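The source may report more compounds than this note shows. Statements on the series, on what has been measured and on what is new or still open speak of the compounds shown alone.

Measured compounds and their values in an assay (Cavia porcellus) for inhibition of Polyunsaturated fatty acid 5-lipoxygenase (Homo sapiens); on this read-out higher numbers stand for weaker inhibition and lower numbers for stronger inhibition:
- compound 1, `NC(=O)N(O)CC1=Cc2cc(OCc3ccc(C(F)(F)F)cc3)ccc2OC1`: 490 nM
- compound 2, `CC(C)(C)c1ccc(Oc2ccc3c(c2)C=C(CN(O)C(N)=O)CO3)cc1`: 1900 nM
- compound 3, `NC(=S)N(O)CC1=Cc2cc(Oc3ccccc3)ccc2OC1`: 200 nM

All three share the same bicyclic core carrying the hydroxylated nitrogen side chain. Compound 3 stands at the lowest number of the three in this assay; its nearest neighbour is compound 1, whose number is higher by a margin beyond the scatter, and compound 2 is furthest, with a considerably higher number. Compound 3 differs from the other two both in the group on the core (a phenoxy rather than a benzyloxy or a substituted phenoxy) and in the group on the hydroxylated nitrogen, so no single-point comparison among the measured compounds is available.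

Compound 4, `CCCCNC(=O)N(O)CC1=Cc2cc(Oc3ccccc3)ccc2OC1`, is not yet measured. It keeps the phenoxy-bearing core of compound 3 and changes only the group on the hydroxylated nitrogen: a group of 7 heavy atoms (5 carbon, 1 nitrogen, 1 oxygen; no ring) in place of a group of 3 heavy atoms (1 carbon, 1 nitrogen, 1 sulfur; no ring), on an amine nitrogen. Among the measured compounds shown here, no measured pair isolates this kind of change, so the direction of the step has to be estimated. The expectation is a modest shift toward a higher number, roughly at or just beyond the scatter, giving an expected step of a 2.5-fold higher number from compound 3 to compound 4 (0.40 log units; beyond the scatter). On that basis compound 4 is estimated at 500 nM, with a range from 150 nM to 2000 nM.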

Compound 4, half-maximal inhibitory concentration: 69 nM
Compound 4: the middle estimate sits 7.2-fold (0.86 log units) above what was measured; measured number outside the range, below it.
By their numbers in this assay, from the lowest: compound 4; then compound 3; then compound 1; then compound 2.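

In this assay, among the compounds shown here, butylcarbamoyl in place of the group of 3 heavy atoms (1 carbon, 1 nitrogen, 1 sulfur), on the amine nitrogen whose other neighbours are oxygen and a saturated chain carbon, gives a 2.9-fold lower number from compound 3 to compound 4 (0.46 log units; beyond the scatter) on the shared core, and this is the first comparison that isolates one place. It shows that this nitrogen carries a much larger group, a no-ring group of 7 heavy atoms, without any loss on this read-out; the number moves down beyond the scatter. No measurement available here bears on what lies behind this step.

The step changes two things at once, the added butyl chain and the exchange of sulfur for oxygen, so the share of each stays unresolved; a plain carbamoyl group, or a methylcarbamoyl group, on the phenoxy-bearing core of compound 3 would separate them. Also open, as far as these compounds go, is how far this position extends, for example to a longer chain such as hexyl, a chain ending in an amine or a carboxylic acid, or a phenyl ring on the carbamoyl nitrogen.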